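The source may report more compounds than this note shows. Statements on the series, on what has been measured and on what is new or still open speak of the compounds shown alone.

Working notes on the series.

Two compounds carry a number in an assay on isolated protein for binding affinity to P2Y purinoceptor 1 (Homo sapiens); a lower number here means a stronger inhibitor, a higher number a weaker inhibitor. Compound 1 `CN(C)CC(C)(C)COc1ccc(NC(=O)Nc2cccnc2Oc2ccccc2[Si](C)(C)C)cc1` gives 163 nM in this assay. Compound 2 `CC(C)(C)c1ccccc1Oc1ncccc1NC(=O)Nc1ccc(OCC2CCN(Cc3ccccc3)CC2)cc1F` gives 11 nM in this assay. Compound 2 stands at the lowest of the two numbers, and the gap from it to compound 1 lies beyond the usual scatter. The two structures differ in several places at once, so the two values show only where each compound stands, not what any single change does.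

Compound 3 `CC(C)CCN1CCC(COc2ccc(NC(=O)Nc3cccnc3Oc3ccccc3C(C)(C)C)c(F)c2)CC1` is not yet measured in this assay. It differs from compound 2 in one place: isobutyl in place of phenyl on a saturated chain carbon bound to an amine nitrogen in a ring. Going by the values given here, no pair of measured compounds shows this change on its own, so there is no measured step to lean on. With the ring on the amine side chain replaced by a shorter open chain and nothing else altered, a modest shift is expected, most likely toward a somewhat higher number or none beyond the scatter, expressed as a 2.0-fold higher number from compound 2 to compound 3 (0.30 log units; within the scatter). Compound 3 is estimated at 22 nM in this assay, within a range of 7 nM to 70 nM.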

Compound 3, inhibition constant in the P2Y purinoceptor 1 assay: 121 nM
Beside the measured number, compound 3's estimate is 5.5-fold (0.74 log units) below it, and the stated range ends below it.
By their numbers in the P2Y purinoceptor 1 assay, from the lowest: compound 2; then compounds 3 and 1 (each within the scatter of the next).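

Going by these compounds alone, in the P2Y purinoceptor 1 assay, isobutyl in place of phenyl on a saturated chain carbon bound to an amine nitrogen in a ring gives an 11-fold higher number from compound 2 to compound 3 (1.04 log units; beyond the scatter), the first reading of a single change on its own. Compounds 1 and 2 differ in several places and could not show this, whereas this pair shows that the position is sensitive to the group it carries, with phenyl the better of the two for binding. In a physicochemical assay for solubility, in phosphate buffer, at pH 6.5 (a lower number here means a less soluble compound, a higher number a more soluble compound), compound 2 gives 2 ug/mL and compound 3 gives 87 ug/mL. In the physicochemical assay, the same change works in the opposite sense, giving a weaker inhibitor but a more soluble compound, so in this one pair the two read-outs pull apart: the measured solubility of compound 2, 2 ug/mL, and of compound 3, 87 ug/mL, a 44-fold higher number (1.64 log units; beyond the scatter)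

The compounds shown leave open whether the aromatic ring itself matters at this position or whether any ring would do, a question that cyclohexyl in place of phenyl would address. On these data alone, it is also open whether binding and solubility can be separated here, for instance with a pyridyl group at the same place, since a single pair cannot show how the two read-outs move together across other groups.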